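Ester ring size across two thiophene placements

The source may hold more compounds than are shown below. What is called first, only, known or untested is meant among the compounds shown, and "the series" means these compounds.

Compound 1 `CC1=C(C(=O)OCC2CC2)C(c2cccs2)NC(=O)N1` gives 1% in an assay on membranes from HeLa cells for displacement of a labelled ligand from adenosine receptor A3 (Homo sapiens), read by scintillation counting, with a stated time of 180 min, tested at 1 uM; a higher number here means more inhibition at the concentration tested (going by the name of the read-out), a lower number less inhibition. Compound 2 `CC1=C(C(=O)OCC2CCC2)C(c2cccs2)NC(=O)N1` gives 1% in this assay, and compound 3 `CC1=C(C(=O)OCC2CC2)C(c2ccsc2)NC(=O)N1` gives 3%. Compound 4 `CC1=C(C(=O)OCC2CCC2)C(c2ccsc2)NC(=O)N1` has not yet been measured; all three measured numbers lie within the scatter of one another, so none is set above the others.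

The change cyclobutyl in place of cyclopropyl on a saturated chain carbon bound to an oxygen next to a carbonyl group made the step of no change at the digits printed from compound 1 to compound 2 (within the scatter). The cores of compounds 1 and 3 differ by thiophen-3-yl in place of thiophen-2-yl on a saturated ring carbon, which made the step of a number 2 percentage points higher from compound 1 to compound 3 (within the scatter). The change cyclobutyl in place of cyclopropyl on a saturated chain carbon bound to an oxygen next to a carbonyl group is the same change as that from compound 1 to compound 2, at the same place on the same kind of chain, now on the core of compound 3.

Compound 4 is expected to move by no change at the digits printed from compound 3 to compound 4 (within the scatter) because the step of no change at the digits printed from compound 1 to compound 2 (within the scatter) stayed within the scatter. Compound 4 is therefore estimated at 3%, expected between -5% and 12%.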

Compound 4, a percentage reported as inhibition, at one concentration (the size of the read-out at that concentration, not a potency): 2%
Estimate against measurement, compound 4: 1 percentage points above, within the range that was stated.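

In this assay, cyclobutyl in place of cyclopropyl gives a number 1 percentage points lower from compound 3 to compound 4 (within the scatter), and this step matches the earlier one on the other core: the same change on two cores in this assay, no change at the digits printed (within the scatter) from compound 1 to compound 2 and a number 1 percentage points lower (within the scatter) from compound 3 to compound 4, 1 percentage points apart, within the scatter of two such steps

Thiophen-3-yl in place of thiophen-2-yl gives a number 1 percentage points higher from compound 2 to compound 4 (within the scatter), and this change also carries across the two esters: the same change on two cores in this assay, a number 2 percentage points higher (within the scatter) from compound 1 to compound 3 and a number 1 percentage points higher (within the scatter) from compound 2 to compound 4, 1 percentage points apart, within the scatter of two such steps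

Within the data shown here, since every step lies within the scatter, this agreement shows only that neither change has a visible effect at the single concentration tested, not that a step of measurable size would carry from one core to another.

Still open, from the compounds shown here alone, is whether a longer chain or an amine on the ester would move the number beyond the scatter. The same question stands for a phenyl group in place of the thiophene.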